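Working notes: from compound 2 to compound 3

The source may hold more compounds than are shown below. What is called first, only, known or untested is meant among the compounds shown, and "the series" means these compounds.

- compound 1 `CC(=O)O[C@@H]1[C@@H](OC(C)=O)[C@@H](O)CO[C@H]1NC(=S)NNC(=O)Cn1cnc2c(N)ncnc21`: > 100000 nM (a limit)
- compound 2 `CC(=O)O[C@@H]1[C@@H](OC(C)=O)[C@@H](O)CO[C@H]1NC(=S)NNC(=O)Cn1cnc2ccccc21`: > 200000 nM (a limit)

Both compounds were tested in a functional assay on Bel-7402 cells (Homo sapiens) for cytotoxicity, read by MTT assay, with a stated time of 48 h; on this read-out lower numbers stand for an effect already at smaller amounts and higher numbers for an effect only at larger amounts of compound. In this assay compound 2 gives > 200000 nM, which is a limit and not a number. Compound 1 gives > 100000 nM, also a limit. For the measured compounds named here, the only measured step is a step that the two limits leave unreadable from compound 1 to compound 2, so the series offers no readable size to carry forward.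

Compound 3 `COc1ccc(C(=O)Nc2nc3ccccc3n2CC(=O)NNC(=S)N[C@@H]2OC[C@H](O)[C@H](OC(C)=O)[C@H]2OC(C)=O)cc1` differs from compound 2 by ((4-methoxyphenyl)carbonyl)amino in place of hydrogen on an aromatic carbon, between two ring nitrogen atoms. Going by the values given here, no measured step involves this change. The expected step, loosely sized and towards lower numbers if it can be read at all, is an at least 2.5-fold lower number from compound 2 to compound 3 (0.39 log units; beyond the scatter). A further limit is also expected to be quite possible. For compound 3 the estimate is 80000 nM, with an expected range of 15000 nM to 250000 nM.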

Compound 3, half-maximal effective concentration: 36700 nM
Compound 3: the middle estimate sits 2.2-fold (0.34 log units) above what was measured, and the stated range covers the measured number.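

In this assay, for the compounds shown here, ((4-methoxyphenyl)carbonyl)amino in place of hydrogen on an aromatic carbon, between two ring nitrogen atoms, gives an at least 5.4-fold lower number from compound 2 to compound 3 (0.73 log units; beyond the scatter) and with it the first readable step. The earlier step from the core of compound 1 to that of compound 2 cannot be read, so this position is the only place shown where a change has a readable direction. The size remains a lower bound, because compound 2 stands at a limit and not at a number: the limit of > 200000 nM in this assay, at which 1 of the 3 values shown sits.

From the compounds shown here alone, it stays open whether the lower number depends on the carbonyl amide link, the phenyl ring or the methoxy group. A plain amine or an unsubstituted benzoylamino group at this position would separate these parts.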